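Chlorobenzyl Positional Series: Estimate for the Para Isomer

The source may hold more compounds than are shown below. What is called first, only, known or untested is meant among the compounds shown, and "the series" means these compounds.

The series shares one core and varies the chlorine on the benzyl group bound to sulfur. Compound 1 `CC1=C(C(=O)Nc2ccc(F)cc2)C(c2ccc([N+](=O)[O-])cc2)N=C(SCc2ccccc2Cl)N1` carries the 2-chlorophenyl group; in a functional assay on the whole organism (artery, strain albino) with Rattus norvegicus as the target, with a stated time of 600 min, at a dose of 10 mg/kg by the oral route (on this read-out lower numbers stand for less inhibition and higher numbers for more inhibition at the one dose given (going by the name of the read-out)), compound 1 gives 17.4%. Compound 2 `CC1=C(C(=O)Nc2ccc(F)cc2)C(c2ccc([N+](=O)[O-])cc2)N=C(SCc2cccc(Cl)c2)N1` carries the 3-chlorophenyl group; in this assay compound 2 gives 16.4%. On the two numbers shown compound 2 is not separated from compound 1: the single measured step reads a number 1 percentage points lower from compound 1 to compound 2 (within the scatter), so moving the chlorine around the ring has so far produced nothing beyond the scatter.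

Compound 3 `CC1=C(C(=O)Nc2ccc(F)cc2)C(c2ccc([N+](=O)[O-])cc2)N=C(SCc2ccc(Cl)cc2)N1` is the third member and is not yet measured. Its difference from compound 2 is 4-chlorophenyl in place of 3-chlorophenyl on a saturated chain carbon bound to a sulfur. Going by the values given here, the only step that bears on it is the one from compound 1 to compound 2, which was within the scatter, and nothing in these two numbers points in either direction. The expected step is therefore a number 0.6 percentage points higher from compound 2 to compound 3 (within the scatter), essentially none beyond the scatter. Compound 3 is estimated at 17% in this assay, with a range from 5% to 29%.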

Compound 3, a percentage reported as inhibition, in the whole organism at one dose (the size of the read-out at that dose, not a potency): 28.2%
Beside the measured number, compound 3's estimate is 11.2 percentage points below it, within the range that was stated.
By their numbers in this assay, from the lowest: compounds 2 and 1 (each within the scatter of the next); then compound 3.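

Placing the chlorine on the 4-chlorophenyl group is the first change in this series to move the number in this assay beyond the scatter, with steps of a number 11.8 percentage points higher from compound 2 to compound 3 (beyond the scatter) and a number 10.8 percentage points higher from compound 1 to compound 3 (beyond the scatter). The position of the chlorine on the group carried by the saturated chain carbon bound to a sulfur therefore does matter in this series, although the step between the 2-chlorophenyl and 3-chlorophenyl groups had suggested otherwise. Among these three compounds, compound 3 alone stands apart, while compound 1 and compound 2 remain within the scatter of each other; the two groups exchanged have the same atoms, so the difference here comes with the chlorine's placement alone, and no supporting data are available to account for it.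

The compounds shown leave open whether the higher number depends on chlorine itself or would persist with a fluorine, a methoxy group or a carboxylic acid in its place on the same ring. They also leave open how a plain benzyl group, with no chlorine on the ring, would compare with the three chlorinated groups.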